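This account rests on a few compounds, and the source may have more. Where it says the series, first, only, none or still open, it means among the compounds named here.

Working notes on the series. In a functional assay on CCRF-CEM cells (Homo sapiens) (on this read-out lower numbers stand for higher toxicity in this test and higher numbers for lower toxicity in this test), compound 1 `Cc1cn([C@@H]2O[C@H](CO[Si](C)(C)C(C)(C)C)[C@@]3(OS(=O)(=O)C=C3NCCC(=O)OCc3ccccc3)[C@H]2O[Si](C)(C)C(C)(C)C)c(=O)n(C)c1=O` gives only a limit, > 250000 nM. Compound 2 `COC(=O)C(=O)CNC1=CS(=O)(=O)O[C@@]12[C@@H](CO[Si](C)(C)C(C)(C)C)O[C@@H](n1cc(C)c(=O)n(C)c1=O)[C@@H]2O[Si](C)(C)C(C)(C)C` gives 5570 nM in this assay, and compound 3 `COC(=O)CC(=O)NC1=CS(=O)(=O)O[C@@]12[C@@H](CO[Si](C)(C)C(C)(C)C)O[C@@H](n1cc(C)c(=O)n(C)c1=O)[C@@H]2O[Si](C)(C)C(C)(C)C` gives 29700 nM. Among the two numbers compound 3 therefore stands highest, its nearest neighbour being compound 2, which sits a step apart by a 5.3-fold higher number from compound 2 to compound 3 (0.73 log units; beyond the scatter). The two steps from the limit, an at least 44-fold lower number from compound 1 to compound 2 (1.65 log units; beyond the scatter) and an at least 8.4-fold lower number from compound 1 to compound 3 (0.92 log units; beyond the scatter), rest on the limit of > 250000 nM in this assay, at which 1 of the 3 values shown sits, and so give only a least size.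

Compound 4 `Cc1cn([C@@H]2O[C@H](CO[Si](C)(C)C(C)(C)C)[C@@]3(OS(=O)(=O)C=C3NCC(=O)C(N)=O)[C@H]2O[Si](C)(C)C(C)(C)C)c(=O)n(C)c1=O` differs from compound 3 at one point: (carbamoylcarbonyl)methyl in place of ((methoxycarbonyl)methyl)carbonyl on an amine nitrogen. The measured step that bears most directly on this change is a 5.3-fold higher number from compound 2 to compound 3 (0.73 log units; beyond the scatter), since compound 2 also carries its carbonyl groups on a chain carbon bound to the amine nitrogen, as compound 4 does, whereas compound 3 bears a carbonyl directly on that nitrogen. The number for compound 4 is therefore expected to fall below that of compound 3, by about a 3.0-fold lower number from compound 3 to compound 4 (0.47 log units; beyond the scatter), landing nearer to compound 2. The estimate for compound 4 in this assay is 10000 nM, with a range from 3000 nM to 40000 nM.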

Compound 4, half-maximal cytotoxic concentration: 9960 nM
Beside the measured number, compound 4's estimate is 1.0-fold (0.00 log units) above it; low and high end bracket the measured number.
By their numbers in this assay, from the lowest: compounds 2 and 4 (each within the scatter of the next); then compound 3. At a limit, above all of these: compound 1.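

In this assay, replacing ((methoxycarbonyl)methyl)carbonyl with (carbamoylcarbonyl)methyl on the amine nitrogen gives a 3.0-fold lower number from compound 3 to compound 4 (0.47 log units; beyond the scatter), so a second compound with the carbonyl-bearing chain carbon bound to that nitrogen also reads apart from compound 3, which has a carbonyl directly on the nitrogen. Among the compounds shown here, the end of that chain is tested for the first time by amino in place of methoxy on a carbonyl carbon, and this exchange gives a 1.8-fold higher number from compound 2 to compound 4 (0.25 log units; within the scatter), so this test does not separate the amide from the methyl ester here. The step of an at least 25-fold lower number from compound 1 to compound 4 (1.39 log units; beyond the scatter) gives only a least size, resting on a limit: the limit of > 250000 nM in this assay, at which 1 of the 4 values shown sits.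

Still open, going by these compounds, is how a carboxylic acid or an N-methyl amide at the end of this chain would read, and whether a longer chain between the amine nitrogen and the two carbonyls would hold the number near those of compound 2 and compound 4. All four compounds carry the same core with its silyl ethers, and the compounds shown do not tell whether these steps keep their size on a core with free hydroxyl groups.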